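Removing the acetyl from compound 1 to give the free amine

The compounds below may be only part of what the source reports. "The series", "measured", "known", "first", "only" and "open" are said of these compounds alone.

Compound 1 `CC(=O)N1c2ccccc2CCC1C(=O)Nc1cc(C(F)(F)F)cc(C(F)(F)F)c1` is known in a functional assay on PC-3 cells (Homo sapiens) for cytotoxicity, read by sulforhodamine B assay, with a stated time of 72 h (on this read-out higher numbers stand for weaker inhibition of growth and lower numbers for stronger inhibition of growth), only by a limit: it gives > 70000 nM, which is the limit of > 70000 nM in this assay, at which 1 of the 2 values shown sits. Compound 2 `O=C(Nc1ccccc1C(F)(F)F)C1CCc2ccccc2N1C(=O)c1ccc(Cl)cc1`, built on the same core with a different acyl group and anilide, gives 786 nM in this assay. Compound 3 `O=C(Nc1cc(C(F)(F)F)cc(C(F)(F)F)c1)C1CCc2ccccc2N1` carries hydrogen in place of acetyl on a nitrogen on an aromatic ring in a ring, a hydrogen in place of acetyl on a nitrogen on an aromatic ring in a ring. With only a limit for compound 1, any step to compound 3 can be judged solely as reaching a number or not; no step beyond the scatter is expected. Compound 3 is expected to give about 45000 nM, between 8000 nM and 90000 nM, a step of an at least 1.5-fold lower number from compound 1 to compound 3 (0.19 log units; that floor lies within the scatter).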

Compound 3, concentration for 50% growth inhibition: 8120 nM
Beside the measured number, compound 3's estimate is 5.5-fold (0.74 log units) above it; measured number inside the range.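

In this assay, replacing the acetyl on this ring nitrogen with hydrogen, with the rest of the molecule unchanged, produces a step of an at least 8.6-fold lower number from compound 1 to compound 3 (0.93 log units; beyond the scatter). This shows that the group on this nitrogen alone can decide whether this anilide gives a measurable number. The value of compound 1 is a limit, not a number, so the step has no upper size: the limit of > 70000 nM in this assay, at which 1 of the 3 values shown sits.

On these data alone, it remains open whether a methyl or a longer acyl chain on this nitrogen would behave like hydrogen or like acetyl. Compound 2 differs from compound 3 in more than one place and cannot settle this.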